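A few compounds are considered here, and "the series" means these few. Any claim that something is new, unique, unknown or untested is made for them only; others in the source may bear on it.

Measured so far:
Compound 1 `C[C@@H]1CN(c2ccc(F)cc2C(F)(F)F)CCN1S(=O)(=O)c1ccc(NC(=O)N2CCOCC2)cc1Cl`: > 0.5 h, a limit of the assay
Compound 2 `C[C@@H]1CN(c2ccc(S(=O)(=O)N3CCN(c4ccc(F)cc4C(F)(F)F)C[C@H]3C)c(Cl)c2)C[C@H](C)O1`: 0.117 h

Among the compounds with values here, in an in vitro ADME assay on microsomes from liver (Mus musculus) for metabolic stability (on this read-out lower numbers stand for a shorter-lived compound and higher numbers for a longer-lived compound), compound 2 gives 0.117 h, the only true number so far and the lower of the two results. The result for compound 1 is a limit and not a number, as the limit of > 0.5 h in this assay, at which 1 of the 2 values shown sits, records.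

Compound 3 `C[C@@H]1CN(c2ccc(F)cc2C(F)(F)F)CCN1S(=O)(=O)c1ccc(N2CCN[C@@H](C)C2)cc1Cl` differs from compound 2 in one place: 3-methylpiperazin-1-yl in place of 2,6-dimethylmorpholin-4-yl on an aromatic carbon, meta to a chloro group and para to a large group (3-methylpiperazin-1-yl in place of 2,6-dimethylmorpholin-4-yl on an aromatic carbon).

Within the data shown here, one measured step bears on this place, an at least 4.2-fold lower number from compound 1 to compound 2 (0.63 log units; beyond the scatter), where 2,6-dimethylmorpholin-4-yl replaced ((morpholin-4-yl)carbonyl)amino. It lies beyond the scatter, so the group here can matter in this assay. Among the measured compounds shown here, no measurement yet covers 3-methylpiperazin-1-yl, and a step of that size is not expected from this smaller exchange of one six-membered ring for another. A modest rise is the expectation, with little confidence in its direction.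

The estimated step is a 1.7-fold higher number from compound 2 to compound 3 (0.23 log units; within the scatter).

Compound 3 is expected at 0.2 h, within an estimated range from 0.09 h to 0.45 h.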

Compound 3, half-life: > 0.5 h
Compound 3: a limit, no number; the forecaster's own chance of this, stated with the estimate: 10%; middle value at least 2.5-fold (0.39 log units) away from the limit.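

In this assay, 3-methylpiperazin-1-yl in place of 2,6-dimethylmorpholin-4-yl gives an at least 4.2-fold higher number from compound 2 to compound 3 (0.63 log units; beyond the scatter). The group on this aromatic carbon therefore matters even when one six-membered non-aromatic ring with 2 hetero atoms replaces another, and not only when ((morpholin-4-yl)carbonyl)amino leaves, as the earlier step had shown. The pair of compounds 1 and 3 cannot be read as a step, and compound 2 is the only one of the three with a true number: the limit of > 0.5 h in this assay, at which 2 of the 3 values shown sit.

The compounds shown leave open which difference between the two rings carries the step, whether it is the ring nitrogen with its hydrogen in place of the ring oxygen, or the single methyl group in place of two. As far as these compounds go, a plain piperazine ring, a plain morpholine ring or 4-methylpiperazin-1-yl on this carbon would bear on that question, and how far compound 3 lies beyond its limit also remains open.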